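Aryl to benzyl on the amine nitrogen

This account rests on a few compounds, and the source may have more. Where it says the series, first, only, none or still open, it means among the compounds named here.

Measured so far:
compound 1 `O=C1C(Nc2ccc(Br)cc2)=CC(=O)c2c1nc1n2[C@H]2OC[C@@H](O)[C@H]2OC1` — 4330 nM
compound 2 `O=C1C(Nc2ccc(C(F)(F)F)cc2)=CC(=O)c2c1nc1n2[C@H]2OC[C@@H](O)[C@H]2OC1` — > 4000 nM

In a functional assay on MCF7 cells (Homo sapiens) for inhibition, read by sulforhodamine B assay (a lower number here means a stronger inhibitor, a higher number a weaker inhibitor), compound 1 gives 4330 nM. Compound 2 sits at the limit of > 4000 nM in this assay, at which 1 of the 2 values shown sits, a limit of the assay and not a number. Among the measured compounds shown here, the one measured step, a step that the limit leaves unreadable from compound 1 to compound 2, is therefore not readable in size. Compound 3 `O=C1C(NCc2ccccc2)=CC(=O)c2c1nc1n2[C@H]2OC[C@@H](O)[C@H]2OC1` differs from compound 2 by benzyl in place of 4-(trifluoromethyl)phenyl on an amine nitrogen. For the measured compounds named here, no measured step touches this exchange, so the expected step that the limit leaves unreadable from compound 2 to compound 3 is set near zero, with wide uncertainty. Compound 3 is estimated at 5000 nM, in a range from 1500 nM to 20000 nM.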

Compound 3, half-maximal inhibitory concentration: > 8000 nM
Compound 3 gave a limit, no number (the forecaster's own chance of this, stated with the estimate: 50%); at least 1.6-fold (0.20 log units) between middle value and limit.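

Moving from an aryl to a benzyl group on the amine nitrogen brings no gain in strength in this assay: the readable result is an at least 1.8-fold higher number from compound 1 to compound 3 (0.26 log units; that floor lies within the scatter), so a loss beyond the scatter is not established. Compound 3 carries a limit and not a number: the limit of > 8000 nM in this assay, at which 1 of the 3 values shown sits. The step between the two limit compounds cannot be read.

Going by these compounds, how far the value of compound 3 lies past its limit stays open. Also open, on these data alone, is whether a longer chain such as phenethyl, or a 4-aminophenyl group, on this nitrogen would give a readable value.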